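Arylpiperazine variation on the oxazole series: T-type channel inhibition

The compounds below may be only part of what the source reports. "The series", "measured", "known", "first", "only" and "open" are said of these compounds alone.

Measured so far:
compound 1 `CCCc1nc(-c2ccccc2)c(CNCCN2CCN(c3cccc(C(F)(F)F)c3)CC2)o1`: 56.3%
compound 2 `CCCc1nc(-c2ccccc2)c(CNCCCN2CCN(c3cccc(C(F)(F)F)c3)CC2)o1`: 51.6%

In an assay on HEK293 cells for inhibition of Voltage-dependent T-type calcium channel subunit alpha-1G (Homo sapiens), read by fluorescence, tested at 10 uM (on this read-out higher numbers stand for more inhibition at the one concentration tested (going by the name of the read-out) and lower numbers for less inhibition), compound 1 gives 56.3% and compound 2 gives 51.6%; the two numbers lie within the scatter of each other, so neither can be set apart from the other on this read-out. Compound 3 `CCCc1nc(-c2ccccc2)c(CNCCN2CCN(c3ccc(OC)cc3)CC2)o1` carries the change 4-methoxyphenyl in place of 3-(trifluoromethyl)phenyl on an amine nitrogen in a ring on the shared core of compound 1. Among the measured compounds shown here, no measured pair shows this change, so its effect is unknown; a moderate drop is expected, and the step from compound 1 to compound 3 in this assay is estimated at a number 16.3 percentage points lower from compound 1 to compound 3 (beyond the scatter). Compound 3 is estimated at 40%, with a range from 15% to 62%.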

Compound 3, a percentage reported as inhibition, at one concentration (the size of the read-out at that concentration, not a potency): 51.5%
For compound 3 the middle estimate is 11.5 percentage points below the measured one; the range from low to high includes it.
By their numbers in this assay, from the lowest: compounds 3, 2 and 1 (each within the scatter of the next).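

Within this assay, putting 4-methoxyphenyl in place of 3-(trifluoromethyl)phenyl on an amine nitrogen in a ring gives a number 4.8 percentage points lower from compound 1 to compound 3 (within the scatter) and so cannot be told apart from no change. This position therefore holds either group with no readable shift in inhibition at the one concentration tested. No measured evidence bears on this result.

Open, from the compounds shown here alone, is whether a plain phenyl, 4-(trifluoromethyl)phenyl or 3-methoxyphenyl on this nitrogen would read apart from these two groups. A single concentration also leaves potency itself open.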